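The compounds below may be only part of what the source reports. "The series", "measured", "known", "first", "only" and "open" are said of these compounds alone.

Measured in a functional assay on the whole organism with Canis familiaris (Canis lupus familiaris) as the target; a higher number here means that more compound is needed for the effect, a lower number that less compound is needed:

Compound 1 `CN1N=C(c2ccc3c(c2)CC(=O)N3)CCC1=O`: 0.271 mg/kg
Compound 2 `CC1CC(=O)NN=C1c1ccc2c(c1)C(C)(C)C(=O)N2C`: 0.0044 mg/kg

Of these two numbers, the lower belongs to compound 2, at 0.0044 mg/kg, while compound 1 stands at 0.271 mg/kg. The gap between them lies beyond the usual scatter, so compound 2 needs less compound for the effect in this assay.

Compound 3 `CN1C(=O)C(C)(C)c2cc(C3=NNC(=O)CC3)ccc21` has not yet been measured. It departs from compound 2 in a single place: hydrogen in place of methyl on a saturated ring carbon. In words, hydrogen replaces methyl on a saturated ring carbon. For the measured compounds named here, no measured pair isolates this change, so the expectation is uncertain. A moderate step in this assay is expected, towards a higher number, probably just beyond the scatter. Going by the values given here, since only this one place changes, compound 3 should remain nearer to compound 2, at 0.0044 mg/kg, than to compound 1, at 0.271 mg/kg. The expected size of the change is a 3.4-fold higher number from compound 2 to compound 3 (0.53 log units; beyond the scatter). For compound 3 the estimated value is 0.015 mg/kg, with an expected range of 0.004 mg/kg to 0.06 mg/kg.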

Compound 3, dose for half-maximal effect: 0.052 mg/kg
Compound 3: middle estimate off by 3.5-fold (0.54 log units), on the low side; the measured number falls inside the stated range.
By their numbers in this assay, from the lowest: compound 2; then compound 3; then compound 1.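

In this assay, for the compounds shown here, putting hydrogen in place of methyl on a saturated ring carbon, next to the ring atom that bears a large group, gives a 12-fold higher number from compound 2 to compound 3 (1.07 log units; beyond the scatter), and this is the first pair that isolates a single change at this position. The position is therefore sensitive: the loss of one methyl, a single carbon with no hydrogen-bond donor, hydrogen-bond acceptor or net charge, is enough to produce a large step, so the methyl is far from a silent addition to the shared core in this assay. The data at hand offer no independent measurement that would account for a step of this size.

The compounds shown leave open whether an ethyl group, a longer chain or a hydroxyl group on this same ring carbon would keep the low number of compound 2 or lose it. They also leave open whether the same exchange of methyl for hydrogen would give a step of similar size on the core of compound 1, which differs from the other two compounds in more than one place.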